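This account rests on a few compounds, and the source may have more. Where it says the series, first, only, none or still open, it means among the compounds named here.

In a functional assay on HepG2 cells (Homo sapiens) for inhibition, read by MTT assay, with a stated time of 24 h (on this read-out higher numbers stand for weaker inhibition and lower numbers for stronger inhibition), compound 1 `CC1(C)[C@H]2CC[C@]1(C)N(Cc1cn(-c3ccccc3)nn1)C(=O)C2` gives 90 nM, compound 2 `CC1(C)[C@H]2CC[C@]1(C)N(Cc1cn(-c3ccc(Br)cc3)nn1)C(=O)C2` gives 110 nM and compound 3 `CC1(C)[C@H]2CC[C@]1(C)N(Cc1cn(-c3ccc(Cl)cc3)nn1)C(=O)C2` gives 90 nM. Compound 3 is thus level with compound 1 and within the scatter of compound 2. Compound 4 `COc1ccc(-n2cc(CN3C(=O)C[C@@H]4CC[C@@]3(C)C4(C)C)nn2)cc1` differs from compound 3 by methoxy in place of chloro on an aromatic carbon. The nearest evidence is two halogen swaps at that place, a 1.2-fold higher number from compound 1 to compound 2 (0.09 log units; within the scatter) and no change at the digits printed from compound 1 to compound 3 (within the scatter), plus a 1.2-fold lower number from compound 2 to compound 3 (0.09 log units; within the scatter). All three stay within the scatter, but none involves methoxy, so the series offers only indirect guidance. The expected change is a 1.1-fold higher number from compound 3 to compound 4 (0.05 log units; within the scatter), with no shift beyond the scatter anticipated. Compound 4 is estimated at 100 nM, within a range of 50 nM to 200 nM.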

Compound 4, half-maximal inhibitory concentration: 100 nM
Estimate against measurement, compound 4: no gap at the digits printed; low and high end bracket the measured number.
By their numbers in this assay, from the lowest: compounds 1, 3, 4 and 2 (each within the scatter of the next).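

Methoxy brings an oxygen and a hydrogen-bond acceptor to this position, which hydrogen, chloro and bromo do not, yet the values stay close: a 1.1-fold higher number from compound 3 to compound 4 (0.05 log units; within the scatter) and a 1.1-fold lower number from compound 2 to compound 4 (0.04 log units; within the scatter) and a 1.1-fold higher number from compound 1 to compound 4 (0.05 log units; within the scatter) are all within the scatter. So these four compounds do not separate methoxy from the smaller groups at this position. Nothing at hand explains why the values sit so close.

Still open, on these data alone, is whether an amine, a carboxylic acid or a longer chain such as butoxy at this position would also stay within the scatter.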